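The source may hold more compounds than are shown below. What is called first, only, known or untested is meant among the compounds shown, and "the series" means these compounds.

The shared core of these compounds carries a saturated chain carbon bound to an oxygen on an aromatic ring, and the group on that carbon is what changes. Compound 1 `N#Cc1ccc(Nc2nccc(OCc3cccnc3)n2)cc1` carries a pyridin-3-yl there. In an ADME assay on MT4 cells (Homo sapiens) for cytotoxicity, read by MTT assay, with a stated time of 5 days (a higher number here means that more compound is tolerated, a lower number that less compound is tolerated), compound 1 gives 6400 nM; of the three numbers in hand, the value of compound 2 stands well above it, while that of compound 3 lies within the scatter of it. Compound 2 `N#Cc1ccc(Nc2nccc(OCc3cccc(Cl)c3)n2)cc1`, with a 3-chlorophenyl, gives 153000 nM, and compound 3 `COc1ccccc1COc1ccnc(Nc2ccc(C#N)cc2)n1`, with a 2-methoxyphenyl, gives 8900 nM. The two steps from compound 1 differ sharply: a 24-fold higher number from compound 1 to compound 2 (1.38 log units; beyond the scatter), whereas a 1.4-fold higher number from compound 1 to compound 3 (0.14 log units; within the scatter). Between the two carbon-only rings, a 17-fold lower number from compound 2 to compound 3 (1.24 log units; beyond the scatter).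

Compound 4 `COc1ccc(COc2ccnc(Nc3ccc(C#N)cc3)n2)cc1` has not yet been measured in this assay. Its difference from compound 1 is 4-methoxyphenyl in place of pyridin-3-yl on a saturated chain carbon bound to an oxygen on an aromatic ring. Both measured steps that swap the pyridin-3-yl for a ring of carbon only bear on this change, one large and one within the scatter, and the methoxyphenyl case is the closer model. Compound 4 is therefore expected to sit near compound 1 or somewhat higher, with a 1.9-fold higher number from compound 1 to compound 4 (0.27 log units; within the scatter) expected as a modest rise rather than a large one. The estimate for compound 4 is 12000 nM, in a range from 5000 nM to 50000 nM.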

Compound 4, half-maximal cytotoxic concentration: 102000 nM
The estimate for compound 4 lay 8.5-fold (0.93 log units) below the measured number; the measured number lies above the stated range.
By their numbers in this assay, from the lowest: compounds 1 and 3 (each within the scatter of the next); then compounds 4 and 2 (each within the scatter of the next).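

Moving the methoxy group on the ring gives an 11-fold higher number from compound 3 to compound 4 (1.06 log units; beyond the scatter) in this assay even though 2-methoxyphenyl and 4-methoxyphenyl are made of the same atoms, so the place of that group on the ring matters and not just its presence. Leaving pyridin-3-yl for 4-methoxyphenyl gives a 16-fold higher number from compound 1 to compound 4 (1.20 log units; beyond the scatter) and so joins the large rise already seen with 3-chlorophenyl, which makes compound 3 the one carbon-only ring that goes against this pattern. The step of a 1.5-fold lower number from compound 2 to compound 4 (0.18 log units; within the scatter) lies within the scatter, so 3-chlorophenyl and 4-methoxyphenyl cannot be told apart here, and no measurement in hand explains why these steps are so large.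

The compounds shown leave open whether the low number of compound 3 belongs to the methoxy group in particular or to any group at that place on the ring, which a 2-chlorophenyl would help to settle. A plain phenyl with no added group would also show whether a carbon-only ring alone is tolerated like 3-chlorophenyl and 4-methoxyphenyl or stays closer to pyridin-3-yl.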